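The compounds below may be only part of what the source reports. "The series", "measured", "known", "first", "only" and "open" are said of these compounds alone.

Among the measured compounds shown here, compound 2 `Cc1ccc(-c2ccnc(C(=O)Nc3ccc(Oc4ccnc5[nH]ccc45)c(F)c3)c2)c(C)c1` is the only compound here with a number in a functional assay on PC-3 cells (Homo sapiens) for cytotoxicity, read by MTT assay, with a stated time of 72 h; a higher number here means a weaker inhibitor, a lower number a stronger inhibitor: compound 2 gives 4010 nM. Compound 1 `O=C(Nc1ccc(Oc2ccnc3[nH]ccc23)c(F)c1)c1cc(-c2ccccc2)ccn1` differs from it only in carrying phenyl where compound 2 carries 2,4-dimethylphenyl. In this assay compound 1 reaches only a limit, > 10000 nM, so its true value is not known. For the measured compounds named here, the one measured step, an at least 2.4-fold lower number from compound 1 to compound 2 (0.39 log units; beyond the scatter), shows that the methyl groups lowered the number at least modestly; how far is open because of the limit of > 10000 nM in this assay, at which 1 of the 2 values shown sits. Compound 3 `O=C(Nc1ccc(Oc2ccnc3[nH]ccc23)c(F)c1)c1cc(-c2ccc(F)cc2)ccn1` carries a different change at the same place: 4-fluorophenyl in place of 2,4-dimethylphenyl on an aromatic carbon. This removes the methyl groups and adds fluorine, bringing the group closer to the phenyl of compound 1 than to the 2,4-dimethylphenyl of compound 2. Going by the values given here, the only bearing step ran the other way, so the expected step, a 2.0-fold higher number from compound 2 to compound 3 (0.30 log units; within the scatter), is toward a higher number, possibly back to a limit. Compound 3 is therefore estimated at 8000 nM, between 3000 nM and 20000 nM.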

Compound 3, half-maximal inhibitory concentration: 710 nM
Beside the measured number, compound 3's estimate is 11-fold (1.05 log units) above it; measured number outside the range, below it.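

Fluoro in place of hydrogen on the phenyl ring gives an at least 14-fold lower number from compound 1 to compound 3 (1.14 log units; beyond the scatter) in this assay, so a single atom at this end of the molecule can separate a compound that reaches only the assay's limit from one with a measured number. Exchanging 2,4-dimethylphenyl for 4-fluorophenyl gives a 5.6-fold lower number from compound 2 to compound 3 (0.75 log units; beyond the scatter), so among these three compounds, 4-fluorophenyl gives the lowest number, and the two methyl groups are not the best of the changes shown. The exact size of the first step remains open because compound 1 has no measured number: the limit of > 10000 nM in this assay, at which 1 of the 3 values shown sits.

The compounds shown leave open whether fluorine itself matters or whether another small group would serve equally well. A chlorine, a single methyl or an amine in place of the fluorine could help settle this.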